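This account rests on a few compounds, and the source may have more. Where it says the series, first, only, none or still open, it means among the compounds named here.

The series shares one core: a chain amide joining an acylamino end to an anilide, tested in a functional assay on HCT-116 cells (Homo sapiens) for inhibition, read by colorimetric assay, with a stated time of 3 days; a lower number here means a stronger inhibitor, a higher number a weaker inhibitor. Compound 1 `NC(=O)C(=O)NCCCCCC(=O)Nc1ccccc1` carries a carbamoylcarbonyl group on the chain nitrogen. In this assay compound 1 gives only a limit, > 100000 nM, the reading standing at the limit of > 100000 nM in this assay, at which 1 of the 3 values shown sits. Compound 2 `O=C(CCCCCCNC(=O)C(O)(O)C(F)(F)F)Nc1ccc(Cl)cc1` and compound 3 `COc1ccc(NC(=O)CCCCCCNC(=O)C(O)(O)C(F)(F)F)cc1` carry a trifluoromethyl-bearing end and substituted anilides; in this assay compound 2 gives 4230 nM and compound 3 gives 4520 nM, a step of a 1.1-fold higher number from compound 2 to compound 3 (0.03 log units; within the scatter). Compound 4 `CC(=O)C(=O)NCCCCCC(=O)Nc1ccccc1` differs from compound 1 by methyl in place of amino on a carbonyl carbon. Going by the values given here, no measured step touches the carbonyl end; the only measured step concerns the aromatic ring and does not bear on this change. The analyst therefore expects compound 4 to stay at the limit, a step of about a number no higher from compound 1 to compound 4 (the limit leaves the size open). The estimate for compound 4 is 100000 nM, ranging from 30000 nM to 300000 nM.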

Compound 4, half-maximal inhibitory concentration: > 100000 nM
Compound 4 gave a limit, no number (the forecaster's own chance of this, stated with the estimate: 70%); the middle value lies on the limit itself.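

Going by these compounds alone, compound 1 and compound 4 both give only a limit in this assay, so no step between them can be read: the limit of > 100000 nM in this assay, at which 2 of the 4 values shown sit. The compounds shown leave open what methyl in place of amino on a carbonyl carbon does to the reading in this assay.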